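The source may hold more compounds than are shown below. What is called first, only, known or untested is meant among the compounds shown, and "the series" means these compounds.

Measured so far in a functional assay on RAW264.7 cells (Mus musculus) for inhibition; on this read-out lower numbers stand for stronger inhibition and higher numbers for weaker inhibition:
- compound 1 `CCOC(=O)C1=CCCCC1S(=O)(=O)Nc1cccc(F)c1`: 150 nM
- compound 2 `CCOC(=O)C1=CCCCC1S(=O)(=O)Nc1cccc(F)c1F`: 140 nM

For the measured compounds named here, compound 1 at 150 nM and compound 2 at 140 nM cannot be told apart, so compound 1 stands level with the only other measured compound.

Not yet measured is compound 3 `CCOC(=O)C1=CCCCC1S(=O)(=O)Nc1nccs1`, which differs from compound 1 as follows: 1,3-thiazol-2-yl in place of 3-fluorophenyl on a sulfonamide nitrogen. In words, 1,3-thiazol-2-yl stands in place of 3-fluorophenyl on a sulfonamide nitrogen.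

Going by the values given here, the only measured step, a 1.1-fold lower number from compound 1 to compound 2 (0.03 log units; within the scatter), is fluoro in place of hydrogen on an aromatic carbon and stays within the scatter. Among the compounds with values here, it bears only weakly on this change, as no measured compound carries anything but a fluorinated phenyl group on the sulfonamide nitrogen.

In this assay, a move to a higher number is tentatively expected, with the estimated step being a 3.3-fold higher number from compound 1 to compound 3 (0.52 log units; beyond the scatter). The estimate for compound 3 is 500 nM, with an expected range of 100 nM to 3000 nM.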

Compound 3, half-maximal inhibitory concentration: > 10000 nM
Compound 3 ended at the assay's limit (the forecaster's own chance of this, stated with the estimate: 8%); at least 20-fold (1.30 log units) between middle value and limit.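

In this assay, for the compounds shown here, 1,3-thiazol-2-yl in place of 3-fluorophenyl on a sulfonamide nitrogen gives an at least 66-fold higher number from compound 1 to compound 3 (1.82 log units; beyond the scatter), while the only earlier change to this aromatic group stayed within the scatter: a 1.1-fold lower number from compound 1 to compound 2 (0.03 log units; within the scatter). Compound 3 gives > 10000 nM, which is a limit of the assay and not a number. The group on the sulfonamide nitrogen therefore matters strongly in this series, which the two fluorinated phenyl compounds alone could not show, and the full size of the step stays unknown, its only bound being: the limit of > 10000 nM in this assay, at which 1 of the 3 values shown sits.

Open, from the compounds shown here alone, is whether the result follows from the ring's sulfur, its nitrogen or its five-membered size; a pyridyl or a thienyl group on the sulfonamide nitrogen would help separate these. Also open, going by these compounds, is whether a carboxylic acid in place of the ethyl ester would be tolerated.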